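Fluoro added to the bromophenyl arm of the series

The source may hold more compounds than are shown below. What is called first, only, known or untested is meant among the compounds shown, and "the series" means these compounds.

The series shares one core, varied only on the aryl group attached to the ring nitrogen. Compound 1 `Cn1ccc2c(Oc3ccc(NC(=O)c4cn(-c5ccc(F)cc5)c5ccccc5c4=O)cc3F)ccnc21` carries a fluoro on that aryl and in a functional assay on MCF7 cells (Homo sapiens) for inhibition, read by MTT assay, with a stated time of 72 h (on this read-out lower numbers stand for stronger inhibition and higher numbers for weaker inhibition), compound 1 stands as "not determined" (no result reported). Compound 2 `Cn1ccc2c(Oc3ccc(NC(=O)c4cn(-c5ccc(Cl)cc5)c5ccccc5c4=O)cc3F)ccnc21` gives 2120 nM in this assay. Compound 3 `Cn1ccc2c(Oc3ccc(NC(=O)c4cn(-c5ccc(Br)cc5)c5ccccc5c4=O)cc3F)ccnc21` gives 1830 nM in this assay; the step of a 1.2-fold lower number from compound 2 to compound 3 (0.06 log units; within the scatter) is within the scatter, so compound 3 and compound 2 sit together on the numbers, with compound 1 adding no number.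

Compound 4 `Cn1ccc2c(Oc3ccc(NC(=O)c4cn(-c5ccc(Br)cc5F)c5ccccc5c4=O)cc3F)ccnc21` is the next step from compound 3: fluoro in place of hydrogen on an aromatic carbon. Going by the values given here, the only measured step, a 1.2-fold lower number from compound 2 to compound 3 (0.06 log units; within the scatter), concerns the exchange of one halogen for another on that aryl and does not cover the addition of a further fluoro on the same ring. Among the compounds with values here, no measured pair therefore bears directly on this change. Within the data shown here, with the one step available inside the scatter and nothing else to go on, the expected step of a 1.0-fold lower number from compound 3 to compound 4 (0.01 log units; within the scatter) in this assay is none beyond the scatter, in either direction. For compound 4 the estimate in this assay is 1800 nM, with a range from 700 nM to 4500 nM.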

Compound 4, half-maximal inhibitory concentration: 420 nM
For compound 4 the middle estimate is 4.3-fold (0.63 log units) above the measured one, outside the stated range (below it).
By their numbers in this assay, from the lowest: compound 4; then compounds 3 and 2 (each within the scatter of the next).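

In this assay, going by these compounds alone, the added fluoro is the first change on this aryl to move the number beyond the scatter: a 4.4-fold lower number from compound 3 to compound 4 (0.64 log units; beyond the scatter), whereas the halogen exchange, a 1.2-fold lower number from compound 2 to compound 3 (0.06 log units; within the scatter), stays within it. Taken as one exchange of the whole aryl on the aromatic nitrogen, the change reads a 5.0-fold lower number from compound 2 to compound 4 (0.70 log units; beyond the scatter), so 4-bromo-2-fluorophenyl gives the lowest number of the measured compounds, with its steps to both others beyond the scatter. Within the data shown here, the step is modest in size, and no measurement at hand accounts for it, so the series so far records the shift without offering a reason for it.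

The compounds shown leave open whether the shift belongs to fluoro specifically or would also follow from a chloro, a methyl or a methoxy group at the same place, ortho to a large group. They also leave open whether it depends on the bromo, since a 4-chloro-2-fluorophenyl arm is not among them, and whether an amine or a carboxylic acid on this ring would keep the lower number.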